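Adding a Methyl to an Aromatic Amine in HL-60 Cells

This account rests on a few compounds, and the source may have more. Where it says the series, first, only, none or still open, it means among the compounds named here.

Compound 1 `CCOC(=O)CC1C(C(=O)OCC)=C(N)Oc2ccc(-c3cccc(N)c3)cc21`: 20200 nM
Compound 2 `CCOC(=O)CC1C(C(=O)OCC)=C(N)Oc2ccc(-c3cccc(NC)c3)cc21`: 7450 nM
Compound 3 `C#CCOC(=O)CC1C(C(=O)OCC#C)=C(N)Oc2ccc(-c3ccc(NC)cc3)cc21`: 2450 nM

Three compounds were tested in a functional assay on HL-60 cells (Homo sapiens) for cytotoxicity, read by CellTiter-Blue, with a stated time of 48 h; on this read-out lower numbers stand for stronger inhibition and higher numbers for weaker inhibition. Compound 1 and compound 2 share one core and differ by a single change, (methyl in place of hydrogen on a nitrogen on an aromatic ring). That change gave a 2.7-fold lower number from compound 1 to compound 2 (0.43 log units; beyond the scatter). Compound 3 carries a different arrangement of groups, and the difference between compound 1 and compound 3 is not broken down here. Among the three, compound 3 gives the lowest number in this assay.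

Compound 4 `C#CCOC(=O)CC1C(C(=O)OCC#C)=C(N)Oc2ccc(-c3ccc(N(C)C)cc3)cc21` has not yet been measured. It differs from compound 3 by methyl in place of hydrogen on a nitrogen on an aromatic ring. Among the measured compounds shown here, this is the same kind of change as the one from compound 1 to compound 2, but not the same: in compound 1 the nitrogen's other neighbour is only an aromatic carbon, while in compound 3 its other neighbours are an aromatic carbon and a saturated chain carbon.

Because a 2.7-fold lower number from compound 1 to compound 2 (0.43 log units; beyond the scatter) was modest yet beyond the scatter, a similar but somewhat smaller step is expected here, giving a 1.6-fold lower number from compound 3 to compound 4 (0.21 log units; within the scatter) in this assay. Compound 4 is therefore estimated at 1500 nM, likely within 600 nM to 4000 nM.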

Compound 4, half-maximal inhibitory concentration: 2560 nM
Compound 4: middle estimate off by 1.7-fold (0.23 log units), on the low side; measured number inside the range.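

In this assay, methyl in place of hydrogen on a nitrogen on an aromatic ring gave a 1.0-fold higher number from compound 3 to compound 4 (0.02 log units; within the scatter), a step too small to separate the two compounds. The lower number seen on the core of compound 1 did not carry over to the core of compound 3, and the two steps clearly differ: the same change on two cores in this assay, a 2.7-fold lower number (0.43 log units; beyond the scatter) from compound 1 to compound 2 and a 1.0-fold higher number (0.02 log units; within the scatter) from compound 3 to compound 4, 2.8-fold (0.45 log units) apart, beyond the scatter of two such steps This shows that the size of this step cannot simply be transferred from one core to another in this series, but it does not show why; the two pairs differ in the ester groups, in where the amine sits on the outer ring and in what else the nitrogen carries, and two pairs cannot tell which of these matters.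

Still open, on these data alone, is whether an ethyl group or a longer chain on this nitrogen would shift the number on either core. Also open, as far as these compounds go, is whether a carboxylic acid in place of the esters would change how the methyl step behaves.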